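Nitro for chloro on the carbonyl-bound ring

The source may hold more compounds than are shown below. What is called first, only, known or untested is meant among the compounds shown, and "the series" means these compounds.

compound 1 `CCCCCCCCCCCCn1nnc(C(NC(=O)c2ccc(C)cc2)c2ccccc2)n1`: 510 nM
compound 2 `CCCCCCCCCCCCn1nnc(C(NC(=O)c2cccc(Cl)c2)c2ccccc2)n1`: 250 nM

In an assay on microsomes from liver for inhibition of sterol O-acyltransferase 1 (Rattus norvegicus) (on this read-out lower numbers stand for stronger inhibition and higher numbers for weaker inhibition), compound 2 holds the lower of the two numbers, the gap being a 2.0-fold lower number from compound 1 to compound 2 (0.31 log units; beyond the scatter). Compound 3 `CCCCCCCCCCCCn1nnc(C(NC(=O)c2cccc([N+](=O)[O-])c2)c2ccccc2)n1` differs from compound 2 by nitro in place of chloro on an aromatic carbon. Among the measured compounds shown here, no measured step covers a nitro group; the only step on record, a 2.0-fold lower number from compound 1 to compound 2 (0.31 log units; beyond the scatter), touches the same ring and is modest, so for compound 3 a step of at most that size in either direction is expected in this assay. Compound 3 is estimated at 300 nM, range 120 nM to 800 nM. This estimate means a step of a 1.2-fold higher number from compound 2 to compound 3 (0.08 log units; within the scatter), expected to stay within the scatter.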

Compound 3, half-maximal inhibitory concentration: 80 nM
Estimate against measurement, compound 3: 3.8-fold (0.57 log units) above; the whole stated range lies above it.
By their numbers in this assay, from the lowest: compound 3; then compound 2; then compound 1.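

At the ring position meta to a large group, the step of a 3.1-fold lower number from compound 2 to compound 3 (0.49 log units; beyond the scatter) in this assay shows that this site still responds when one substituent replaces another in the same place, and not only when the substitution pattern of the ring changes. Among the compounds shown here, the step of a 6.4-fold lower number from compound 1 to compound 3 (0.80 log units; beyond the scatter) is the largest so far, and it comes with 3-nitrophenyl on the carbonyl carbon. Nothing measured accounts for the nitro result.

Going by these compounds, whether a nitrile or a carboxylic acid at this position would give a lower number stays open. Also open, on these data alone, is whether the 3-nitrophenyl result would hold with a shorter chain on the core.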